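Urea in place of benzamide on the shared core

The compounds below may be only part of what the source reports. "The series", "measured", "known", "first", "only" and "open" are said of these compounds alone.

Measured compounds:
compound 1, `COc1cc(-c2nn(-c3cccc(NC(=O)Nc4cccc(C(F)(F)F)c4)c3)cc2-c2ccncc2)ccc1Cl`, 573 nM 
compound 2, `COc1cc(-c2nn(-c3cccc(NC(=O)Nc4ccc(Cl)c(C(F)(F)F)c4)c3)cc2-c2ccncc2)ccc1Cl`, 1060 nM 
compound 3, `COc1cc(-c2nn(-c3cccc(NC(=O)c4ccccc4)c3)cc2-c2ccncc2)ccc1Cl`, 556 nM 

Compound 3 gives the lowest number of the three in a functional assay on KM12 cells (Homo sapiens) for inhibition, read by sulforhodamine B assay, with a stated time of 48 h (on this read-out higher numbers stand for weaker inhibition of growth and lower numbers for stronger inhibition of growth), but the two steps that lead to it, a 1.0-fold lower number from compound 1 to compound 3 (0.01 log units; within the scatter) and a 1.9-fold lower number from compound 2 to compound 3 (0.28 log units; within the scatter), are both within the scatter, so no order among them can be read.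

Compound 4, `COc1cc(-c2nn(-c3cccc(NC(=O)Nc4ccc(Cl)c(Cl)c4)c3)cc2-c2ccncc2)ccc1Cl`, has not been measured. Its difference from compound 3 is (3,4-dichlorophenyl)amino in place of phenyl on a carbonyl carbon; cut one bond further out, this reads benzamido to ((3,4-dichlorophenyl)carbamoyl)amino. Among the compounds with values here, the steps that bear on it are the two in which a substituted phenylamino on the carbonyl carbon gives way to phenyl: a 1.0-fold lower number from compound 1 to compound 3 (0.01 log units; within the scatter) and a 1.9-fold lower number from compound 2 to compound 3 (0.28 log units; within the scatter). Neither exceeds the scatter, and the second chloro added from compound 1 to compound 2 gave a 1.8-fold higher number from compound 1 to compound 2 (0.27 log units; within the scatter). A step of a 1.3-fold higher number from compound 3 to compound 4 (0.13 log units; within the scatter) is therefore expected, no more than the scatter allows. Compound 4 is estimated at 750 nM, with a range from 350 nM to 1600 nM.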

Compound 4, concentration for 50% growth inhibition: 811 nM
Beside the measured number, compound 4's estimate is 1.1-fold (0.03 log units) below it, and the stated range covers the measured number.
By their numbers in this assay, from the lowest: compounds 3, 1, 4 and 2 (each within the scatter of the next).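

In this assay, a urea bearing a (3,4-dichlorophenyl)amino group on the carbonyl carbon also stays within the scatter of the benzamide, with a 1.5-fold higher number from compound 3 to compound 4 (0.16 log units; within the scatter), so all three ureas now shown fall within the scatter of compound 3, and none goes against this. Among the ureas, the aryl substitution can also be varied without a step that exceeds the scatter, as seen in a 1.3-fold lower number from compound 2 to compound 4 (0.12 log units; within the scatter) and a 1.4-fold higher number from compound 1 to compound 4 (0.15 log units; within the scatter). No evidence is available to explain these results.

As far as these compounds go, it remains open whether a carboxylic acid or an amine on the terminal phenyl ring would give a step beyond the scatter. The same question stands for a longer alkyl chain in place of that ring on the carbonyl carbon.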